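The source may report more compounds than this note shows. Statements on the series, on what has been measured and on what is new or still open speak of the compounds shown alone.

Measured so far in an ADME assay on CCRF-CEM cells (Homo sapiens) for cytotoxicity, with a stated time of 4 days; a higher number here means that more compound is tolerated, a lower number that less compound is tolerated:

- compound 1 `CNC(=O)CCCCn1c(=O)c(C)cn([C@@H]2O[C@H](CO[Si](C)(C)C(C)(C)C)[C@@]3(OS(=O)(=O)C=C3N)[C@H]2O[Si](C)(C)C(C)(C)C)c1=O`: 10000 nM
- compound 2 `COC(=O)n1c(=O)c(C)cn([C@@H]2O[C@H](CO[Si](C)(C)C(C)(C)C)[C@@]3(OS(=O)(=O)C=C3N)[C@H]2O[Si](C)(C)C(C)(C)C)c1=O`: > 100000 nM (a limit of the assay, not a number)

Going by the values given here, of these two compounds, compound 1 is the only one with an actual number, 10000 nM, so it has no measured value to be ranked against. Compound 3 `Cc1cn([C@@H]2O[C@H](CO[Si](C)(C)C(C)(C)C)[C@@]3(OS(=O)(=O)C=C3N)[C@H]2O[Si](C)(C)C(C)(C)C)c(=O)n(C(=O)C2CC2)c1=O` has not yet been measured. It carries cyclopropylcarbonyl in place of 4-(methylcarbamoyl)butyl on an aromatic nitrogen.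

Among the compounds with values here, only one measured step bears on this change. In an at least 10-fold higher number from compound 1 to compound 2 (1.00 log units; beyond the scatter), the same 4-(methylcarbamoyl)butyl leaves the same aromatic nitrogen and methoxycarbonyl enters, and that step lies beyond the scatter. Within the data shown here, both entering groups are named as carbonyl groups, but they are not the same group, and this single step is the only guide. A rise in this assay is therefore expected, though a smaller one than an at least 10-fold higher number from compound 1 to compound 2 (1.00 log units; beyond the scatter) is a cautious assumption. The expected step is a 4.0-fold higher number from compound 1 to compound 3 (0.60 log units; beyond the scatter). For compound 3 the estimated value is 40000 nM, with an expected range of 12000 nM to 100000 nM.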

Compound 3, half-maximal cytotoxic concentration: 11000 nM
The estimate for compound 3 lay 3.6-fold (0.56 log units) above the measured number; measured number outside the range, below it.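

In this assay, cyclopropylcarbonyl on the aromatic nitrogen gives a 1.1-fold higher number from compound 1 to compound 3 (0.04 log units; within the scatter), so a carbonyl on this nitrogen in place of 4-(methylcarbamoyl)butyl is not enough on its own to produce a difference beyond the scatter. The earlier step, an at least 10-fold higher number from compound 1 to compound 2 (1.00 log units; beyond the scatter), therefore cannot be read as the result of any carbonyl group at this position. What is attached to the carbonyl carbon matters in this pair, since cyclopropyl in place of methoxy gives an at least 9.0-fold lower number from compound 2 to compound 3 (0.95 log units; beyond the scatter), although compound 2 stands at a limit of the assay, not a number: the limit of > 100000 nM in this assay, at which 1 of the 3 values shown sits.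

The compounds shown leave open whether the oxygen of the methoxy group or the cyclopropyl ring is what separates these two carbonyl groups, and an ethoxycarbonyl or a plain acetyl group on the same nitrogen would help to tell these readings apart. They also leave open how a dimethylamine on the carbonyl carbon, or a shorter chain ending in the same methyl amide, would read in this assay.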